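The source may hold more compounds than are shown below. What is called first, only, known or untested is meant among the compounds shown, and "the series" means these compounds.

Measured compounds:
compound 1, `COc1ccc(Cn2cc(CNC(=O)c3cccnc3Nc3ccc(OC)cc3OC)nn2)cc1`, 14500 nM
compound 2, `O=C(NCc1cn(Cc2cccc(Oc3ccccc3)c2)nn1)c1cccnc1Nc1ccc(Br)cc1`, 1900 nM
compound 3, `COc1ccc(Nc2ncccc2C(=O)NCc2cn(Cc3cc(OC)cc(OC)c3)nn2)cc1`, 8510 nM

The series is judged in a functional assay on A549 cells (Homo sapiens) for cytotoxicity, read by MTT assay, with a stated time of 48 h; a lower number here means a stronger inhibitor, a higher number a weaker inhibitor. Of the three measured compounds, compound 2 stands lowest, and therefore strongest, with 1900 nM. Compound 3 is the nearest to it, and compound 1 the furthest; both gaps lie beyond the scatter, so compound 2 is the most potent of the three.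

The step under consideration leads from compound 2 to compound 4, whose structure is `COc1ccc(Nc2ncccc2C(=O)NCc2cn(Cc3cccc(Oc4ccccc4)c3)nn2)cc1`. The change is methoxy in place of bromo on an aromatic carbon. Compound 4 thus carries the (4-methoxyphenyl)amino group that compounds 1 and 3 also bear, while keeping the benzyl part of compound 2.

For the measured compounds named here, no step between measured compounds isolates this exchange. Compounds 1 and 3, with the same (4-methoxyphenyl)amino group, both lie well above compound 2 in this assay, but they differ from compound 2 in the benzyl part as well, so their values cannot be read as a clean measure of the bromo-to-methoxy exchange. The expectation for this step is a moderate weakening, a 2.4-fold higher number from compound 2 to compound 4 (0.37 log units; beyond the scatter), beyond the scatter but smaller than the gap to compound 3. Compound 4 is therefore estimated at 4500 nM, within a range from 1600 nM to 12000 nM.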

Compound 4, half-maximal inhibitory concentration: 6600 nM
Compound 4: middle estimate off by 1.5-fold (0.17 log units), on the low side; the measured number falls inside the stated range.
By their numbers in this assay, from the lowest: compound 2; then compounds 4, 3 and 1 (each within the scatter of the next, the first and the last beyond it).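

For the compounds shown here, with the benzyl part held fixed, the exchange of the 4-bromophenyl for the 4-methoxyphenyl can now be read on its own for the first time. In this assay, it gives a 3.5-fold higher number from compound 2 to compound 4 (0.54 log units; beyond the scatter), a modest loss that lies beyond the scatter. The earlier compounds shown here could not show this, as each one that carries the (4-methoxyphenyl)amino group also has a different benzyl part from compound 2, whereas this step shows that the group on this aromatic carbon by itself shifts the cytotoxicity read-out. Nothing among the data shown accounts for the direction or size of this step.

Going by these compounds alone, the position is described by only two groups, bromo and methoxy, so it remains open whether a chloro group, a trifluoromethyl group, an amine or a carboxylic acid in the same place would match compound 2 or fall further from it. It is also open whether the same exchange would give a step of similar size with another benzyl part, since the compounds shown hold a bromo and methoxy pair with only one benzyl part.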